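Replacing thiophen-2-yl with 4-carboxycyclohexyl in compound 3

The source may hold more compounds than are shown below. What is called first, only, known or untested is meant among the compounds shown, and "the series" means these compounds.

compound 1 `Oc1ccc(CN(Cc2ccccc2)Cc2ccc(O)c3ncccc23)c2cccnc12`: 544 nM
compound 2 `Oc1ccc(CN(Cc2cccc(I)c2)Cc2ccc(O)c3ncccc23)c2cccnc12`: 350 nM
compound 3 `Oc1ccc(CN(Cc2cccs2)Cc2ccc(O)c3ncccc23)c2cccnc12`: 27 nM

These values come from a functional assay on A549 cells (Homo sapiens) for cytotoxicity, read by MTT assay; a higher number here means a weaker inhibitor, a lower number a stronger inhibitor. Compound 3 has the lowest number of the three, and its gaps to both others lie beyond the scatter. Compound 4 `O=C(O)C1CCC(CN(Cc2ccc(O)c3ncccc23)Cc2ccc(O)c3ncccc23)CC1` has not yet been measured. It differs from compound 3 by 4-carboxycyclohexyl in place of thiophen-2-yl on a saturated chain carbon bound to an amine nitrogen.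

Within the data shown here, no measured compound carries the entering group, so the evidence is indirect. At this same place, two large steps favour thiophen-2-yl: a 20-fold lower number from compound 1 to compound 3 (1.30 log units; beyond the scatter) and a 13-fold lower number from compound 2 to compound 3 (1.11 log units; beyond the scatter). By contrast, a 1.6-fold lower number from compound 1 to compound 2 (0.19 log units; within the scatter) stays within the scatter. The low number therefore belongs to compound 3 alone, and it may not survive losing thiophen-2-yl. A large step toward a higher number is expected, of similar size to those two, and it is estimated as a 19-fold higher number from compound 3 to compound 4 (1.27 log units; beyond the scatter). Compound 4 is estimated at 500 nM, with an expected range from 90 nM to 3000 nM.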

Compound 4, half-maximal inhibitory concentration: 661 nM
For compound 4 the middle estimate is 1.3-fold (0.12 log units) below the measured one; the measured number falls inside the stated range.
By their numbers in this assay, from the lowest: compound 3; then compounds 2, 1 and 4 (each within the scatter of the next).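

In this assay, the large step of a 24-fold higher number from compound 3 to compound 4 (1.39 log units; beyond the scatter) shows that the low number of compound 3 is also lost when a non-aromatic carbon ring bearing a carboxylic acid enters on this saturated chain carbon bound to an amine nitrogen. The comparisons of a 1.9-fold higher number from compound 2 to compound 4 (0.28 log units; within the scatter) and of a 1.2-fold higher number from compound 1 to compound 4 (0.08 log units; within the scatter) both stay within the scatter, so 4-carboxycyclohexyl cannot be told apart from phenyl or 3-iodophenyl here, and among the groups shown only thiophen-2-yl stands out. Nothing available explains why thiophen-2-yl alone gives this result.

On these data alone, it remains open whether the low number needs the sulfur of thiophen-2-yl, which a furan-2-yl group at this place could test. A plain cyclohexyl group could likewise separate the part played by the ring from that of the carboxylic acid.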